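From a Bromophenyl to a Nitrophenyl on a Shared Core

The source may hold more compounds than are shown below. What is called first, only, known or untested is meant among the compounds shown, and "the series" means these compounds.

compound 1 `CC1=C(C(=O)Nc2ccc([N+](=O)[O-])cc2)C(c2ccc(Br)cc2)N=C(SCc2ccccc2Cl)N1`: 11.3%
compound 2 `CC1=C(C(=O)Nc2ccc([N+](=O)[O-])cc2)C(c2ccc(Br)cc2)N=C(SCc2ccc(Cl)cc2)N1`: 19.1%

Among the compounds with values here, in a functional assay on the whole organism (artery, strain albino) with Rattus norvegicus as the target, with a stated time of 180 min, at a dose of 10 mg/kg by the oral route (a higher number here means more inhibition at the dose given (going by the name of the read-out), a lower number less inhibition), compound 1 gives 11.3%, the lowest of the two numbers so far; the nearest is compound 2 with 19.1%, a gap within the scatter, so the two cannot be ranked against each other. Compound 3 `CC1=C(C(=O)Nc2ccc([N+](=O)[O-])cc2)C(c2cccc([N+](=O)[O-])c2)N=C(SCc2ccccc2Cl)N1` has not yet been measured. Within the data shown here, it differs from compound 1 in one place: 3-nitrophenyl in place of 4-bromophenyl on a saturated ring carbon The only measured step, a number 7.8 percentage points higher from compound 1 to compound 2 (within the scatter), concerns a different part of the molecule, the (2-chlorobenzyl)sulfanyl group, and stays within the scatter, so it says nothing about an exchange on the saturated ring carbon. Among the measured compounds shown here, no measured step bears on this change, and no direction can be read from the data. Compound 3 is therefore expected to give about 14% in this assay, with a range from 2% to 35%. The step of a number 2.7 percentage points higher from compound 1 to compound 3 (within the scatter) is estimated to stay within the scatter, with wide uncertainty.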

Compound 3, a percentage reported as inhibition, in the whole organism at one dose (the size of the read-out at that dose, not a potency): 9.3%
Beside the measured number, compound 3's estimate is 4.7 percentage points above it; the range from low to high includes it.
By their numbers in this assay, from the lowest: compounds 3, 1 and 2 (each within the scatter of the next).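

Putting 3-nitrophenyl in place of 4-bromophenyl on the saturated ring carbon gives a number 2 percentage points lower from compound 1 to compound 3 (within the scatter) in this assay. Within the data shown here, this is the first measured step at this position, and it shows that exchanging a group of 7 heavy atoms and 0 hydrogen-bond acceptors for one of 9 heavy atoms and 2 hydrogen-bond acceptors gives no difference that can be told from the scatter. Nothing measured here offers an explanation for this result.

As far as these compounds go, whether an aminophenyl group or a carboxylic acid on this saturated ring carbon would give a step beyond the scatter remains open. Also open, from the compounds shown here alone, is whether 3-nitrophenyl would give a similar result alongside the (4-chlorobenzyl)sulfanyl group of compound 2.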